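Replacing a sulfur link with oxygen on a compound with a high number

The compounds below may be only part of what the source reports. "The series", "measured", "known", "first", "only" and "open" are said of these compounds alone.

Of the compounds shown here, three built on a shared core have been tested in an assay on isolated protein for inhibition of leukotriene B4 receptor 1 (Homo sapiens), tested at 10 uM; a lower number here means less inhibition, a higher number more inhibition at the concentration tested (going by the name of the read-out). Compound 1 `CC(=O)c1ccc(OCCCCC#N)cc1O` gives 0%. Compound 2 `CCc1cc(C(C)=O)c(O)cc1OCCCCCCC#N` gives 103%. Compound 3 `CSCc1cc(C(C)=O)c(O)cc1OCCCCCCC#N` gives 97%. On these numbers compound 3 stands second highest of the three: compound 2 is nearest, within the usual scatter of repeated measurements, while compound 1 lies far lower, beyond that scatter. Among the measured compounds shown here, the only measured step that changes a single place, a number 6 percentage points lower from compound 2 to compound 3 (within the scatter), stayed within the scatter.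

Compound 4 `COCc1cc(C(C)=O)c(O)cc1OCCCCCCC#N` has not yet been measured. It differs from compound 3 in one place: methoxy in place of methylsulfanyl on a saturated chain carbon bound to an aromatic carbon. For the measured compounds named here, the one measured step at this same place bears on the question because a number 6 percentage points lower from compound 2 to compound 3 (within the scatter) was within the scatter, suggesting that the group on this chain carbon matters little here. The step of a number 3 percentage points lower from compound 3 to compound 4 (within the scatter) is therefore expected to stay within the scatter. Compound 4 is estimated to give about 94%, with a likely range from 78% to 105%.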

Compound 4, a percentage reported as inhibition, at one concentration (the size of the read-out at that concentration, not a potency): 47%
Estimate against measurement, compound 4: 47 percentage points above; measured number outside the range, below it.
By their numbers in this assay, from the lowest: compound 1; then compound 4; then compounds 3 and 2 (each within the scatter of the next).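

The group on this chain carbon turns out to matter after all: in this assay, methoxy in place of methylsulfanyl gives a number 50 percentage points lower from compound 3 to compound 4 (beyond the scatter), although the two groups match in heavy-atom count and hydrogen-bond acceptors. Methoxy in place of methyl likewise gives a number 56 percentage points lower from compound 2 to compound 4 (beyond the scatter), so this position accepts methyl and methylsulfanyl with numbers within the scatter of each other, but not methoxy. Nothing available explains why oxygen and sulfur part ways here.

Going by these compounds, whether a hydroxyl, an amine or a longer chain on this carbon would stay near compound 3 or fall towards compound 4 remains open. On these data alone, these numbers come from one concentration and are not potencies, so how far the compounds differ in potency also remains open.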